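The source may report more compounds than this note shows. Statements on the series, on what has been measured and on what is new or still open speak of the compounds shown alone.

The measured compounds:

Compound 1, `CN(C)CCCOc1ccc(CN2CC[C@H](NC(=O)c3ccccc3)C2)cc1`, gives 2510 nM in an assay on HEK293 cells for binding affinity to Urotensin-2 receptor (Homo sapiens), read by radioligand binding; a higher number here means a weaker inhibitor, a lower number a stronger inhibitor.
Compound 3, `CN(C)CCCOc1ccc(CN2CC[C@H](NC(=O)c3cc4ccccc4o3)C2)cc1`, gives 2510 nM in this assay.
Compound 2, `CN(C)CCCOc1ccc(CN2CC[C@H](NC(=O)c3cccs3)C2)cc1`, is reported in this assay only as a limit, < 10000 nM.

The three share a core and differ only in the group on the carbonyl carbon. The step of no change at the digits printed from compound 1 to compound 3 (within the scatter) is within the scatter. Because compound 2 sits at the limit of < 10000 nM in this assay, at which 1 of the 3 values shown sits, the steps a step that the limit leaves unreadable from compound 1 to compound 2 and a step that the limit leaves unreadable from compound 2 to compound 3 cannot be sized, so compound 2 stands somewhere under that limit, with no firmer number.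

Compound 4, `CC(=O)N[C@@H](CC(C)C)C(=O)N[C@H]1CCN(Cc2ccc(OCCCN(C)C)cc2)C1`, has not been measured. It differs from compound 2 in one place: 1-acetamido-3-methylbutyl in place of thiophen-2-yl on a carbonyl carbon. Among the compounds with values here, no measured step replaces an aromatic group on this carbonyl carbon with an open chain of this kind, so none of the steps above bears directly on it; the only guide is that the two readable neighbours of compound 2 lie close together and its own value is a limit. Compound 4 is therefore expected to land in the same region, and the step that the limit leaves unreadable from compound 2 to compound 4 is estimated to be of unknown direction and modest size. The estimate for compound 4 in this assay is 3000 nM, with a range from 500 nM to 20000 nM.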

Compound 4, inhibition constant: 2510 nM
Estimate against measurement, compound 4: 1.2-fold (0.08 log units) above; the range from low to high includes it.
By their numbers in this assay, from the lowest: compounds 1, 3 and 4 (each within the scatter of the next).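

In this assay, putting 1-acetamido-3-methylbutyl, a group with no ring, on the carbonyl carbon in place of an aromatic group gives no change at the digits printed from compound 1 to compound 4 (within the scatter) and no change at the digits printed from compound 3 to compound 4 (within the scatter). Among compound 1, compound 3 and compound 4, an aromatic ring at this position is therefore not needed to keep the value where it stands, and the open chain with its hydrogen-bond donor leaves that value in the same place. Compound 2 remains only a limit, so the steps to and from it cannot be read: the limit of < 10000 nM in this assay, at which 1 of the 4 values shown sits.

The compounds shown leave open whether a free amine or a carboxylic acid in place of the acetamido part, or a longer chain, would move the value beyond the scatter. They also leave open whether the defined stereocentre of the chain matters.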